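The compounds below may be only part of what the source reports. "The series", "measured", "known", "first", "only" and "open" are said of these compounds alone.

- Compound 1 `COc1ccc(/C=C2\CN(C)C/C(=C\c3cccnc3)C2=O)c(OC)c1OC` gives 5160 nM here
- Compound 2 `Cc1ccc(S(=O)(=O)N2C/C(=C\c3cccnc3)C(=O)/C(=C/c3ccccc3F)C2)cc1` gives 4200 nM here
- Compound 3 `Cc1ccc(S(=O)(=O)N2C/C(=C\c3cccnc3)C(=O)/C(=C/c3ccccc3C(F)(F)F)C2)cc1` gives 2930 nM here

All three values come from a functional assay on HepG2 cells (Homo sapiens) for cytotoxicity, read by MTT assay, with a stated time of 24 h (on this read-out lower numbers stand for stronger inhibition and higher numbers for weaker inhibition), and lie close together. Compound 3 sits within the scatter of both compound 2 and compound 1, so no order can be drawn among them, even though compound 1 differs from compound 3 in more than one place.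

Compound 4 `N#Cc1ccc(S(=O)(=O)N2C/C(=C\c3cccnc3)C(=O)/C(=C/c3ccccc3C(F)(F)F)C2)cc1` departs from compound 3 by a single change, (cyano in place of methyl on an aromatic carbon), with cyano in place of methyl on an aromatic carbon, para to a large group. The 4-methylphenyl thus becomes 4-cyanophenyl.

For the measured compounds named here, only one measured step bears on this, and only indirectly. The step of a 1.4-fold lower number from compound 2 to compound 3 (0.16 log units; within the scatter) is small and changes a different place in the molecule. Going by the values given here, no measured step touches the (4-methylphenyl)sulfonyl group, so nothing beyond the scatter is expected in this assay, and no direction can be favoured. The expected step is a 1.0-fold lower number from compound 3 to compound 4 (0.00 log units; within the scatter), which is an estimate only. For compound 4 the estimated value is 2900 nM, with an expected range from 1200 nM to 6800 nM, and the measurement follows.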

Compound 4, half-maximal inhibitory concentration: 5060 nM
The estimate for compound 4 lay 1.7-fold (0.24 log units) below the measured number, within the range that was stated.
By their numbers in this assay, from the lowest: compounds 3, 2, 4 and 1 (each within the scatter of the next).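

This is the only step shown at the (4-methylphenyl)sulfonyl group, and in this assay it reads a 1.7-fold higher number from compound 3 to compound 4 (0.24 log units; within the scatter). Cyano in place of methyl on this aromatic carbon, para to a large group, therefore does not separate the two compounds, so this position tolerates the exchange without a readable shift in the number. The earlier step, a 1.4-fold lower number from compound 2 to compound 3 (0.16 log units; within the scatter), concerned a different place and could not show this. Nothing available explains the values of these compounds.

On these data alone, it remains open whether an amine or a carboxylic acid on this aromatic carbon, or a longer chain such as butyl, would move the number beyond the scatter. Also open, as far as these compounds go, is whether cyano in place of methyl would read the same alongside the fluoro group of compound 2.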